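The source may hold more compounds than are shown below. What is called first, only, known or untested is meant among the compounds shown, and "the series" means these compounds.

Compound 1, `COc1cc(-c2cc3nccc(-c4cc(OC)c(OC)c(OC)c4)n3n2)cc(OC)c1OC`. In a functional assay on HCT-116 cells (Homo sapiens) for inhibition, read by CCK-8 assay, with a stated time of 48 h (on this read-out higher numbers stand for weaker inhibition and lower numbers for stronger inhibition), compound 1 gives only a limit, > 10000 nM.
Compound 2, `COc1cc(-c2ccnc3cc(-c4ccc(C)c(C)c4)nn23)cc(OC)c1OC`. In this assay compound 2 gives 261 nM.
Compound 3, `COc1cc(-c2ccnc3cc(-c4cccc(C#N)c4)nn23)cc(OC)c1OC`. In this assay compound 3 gives only a limit, > 10000 nM.

For the measured compounds named here, compound 2 stands alone as the only actual number in this assay: the two further values are the limit of > 10000 nM in this assay, at which 2 of the 3 values shown sit, so compound 2 is the sole anchor for any comparison among the three.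

Compound 4 is `COc1cc(-c2ccnc3cc(-c4ccc(C(C)=O)cc4)nn23)cc(OC)c1OC`. It differs from compound 2 in one place: 4-acetylphenyl in place of 3,4-dimethylphenyl on an aromatic carbon.

Going by the values given here, the only measured step that bears on this change is the one in which the 3,4-dimethylphenyl of compound 2 was also replaced at the same aromatic carbon: an at least 38-fold higher number from compound 2 to compound 3 (1.58 log units; beyond the scatter). That was a large loss, reaching the limit of this assay. Among the compounds with values here, a different replacement at the same place is not a repeat of that step, but it is the closest evidence at hand, and no second example shows a replacement there surviving.

Compound 4 is therefore expected to sit weaker than compound 2, with an 11-fold higher number from compound 2 to compound 4 (1.06 log units; beyond the scatter). The estimate for compound 4 in this assay is 3000 nM, with a range from 500 nM to 12000 nM, and a real chance that only a limit is reported.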

Compound 4, half-maximal inhibitory concentration: 4390 nM
For compound 4 the middle estimate is 1.5-fold (0.17 log units) below the measured one; the measured number falls inside the stated range.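

Of the two replacements of 3,4-dimethylphenyl shown at this aromatic carbon, 4-acetylphenyl is the one that gives an actual number in this assay, so a change here need not end at the limit, although the cost remains large: a 17-fold higher number from compound 2 to compound 4 (1.23 log units; beyond the scatter). The two replacements are also not interchangeable at this position, as the step between them lies beyond the scatter: an at least 2.2-fold lower number from compound 3 to compound 4 (0.35 log units; beyond the scatter). That second step is read against a limit rather than a number, and such values remain common in this small set: the limit of > 10000 nM in this assay, at which 2 of the 4 values shown sit.

On these data alone, whether the loss goes with the arrival of the acetyl group or with the departure of the two methyl groups stays open, and a plain phenyl or a 4-methylphenyl at this carbon would be needed to separate the two. As far as these compounds go, how an amine or a carboxylic acid on this ring would fare also remains unknown, as does whether any group here can match or improve on the 3,4-dimethylphenyl.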